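The compounds below may be only part of what the source reports. "The series", "measured", "known", "first", "only" and "open" are said of these compounds alone.

Compound 1 `Cc1cc(Oc2ccccc2OCCn2ccc(=O)[nH]c2=O)c2cc(C#N)[nH]c2c1` gives 1200 nM in an ADME assay on MT2 cells (Homo sapiens) for cytotoxicity, read by MTT assay (a lower number here means that less compound is tolerated, a higher number that more compound is tolerated), the lowest of the three numbers recorded there. Compound 3 `N#Cc1ccc2c(Oc3ccccc3OCCn3ccc(=O)[nH]c3=O)cc(Cl)cc2c1` gives 24000 nM in this assay, and compound 2 `N#Cc1cc2c(Oc3ccc(F)cc3OCCn3ccc(=O)[nH]c3=O)cc(F)cn2c1` gives 50000 nM, each lying beyond the scatter from compound 1. Compound 4 `N#Cc1cc2c(Oc3ccccc3OCCn3ccc(=O)[nH]c3=O)cc(Cl)cc2[nH]1` has not yet been measured in this assay. It differs from compound 1 in a single place: chloro in place of methyl on an aromatic carbon. For the measured compounds named here, no pair of measured compounds differs in that place alone, so the expectation rests on compound 1 and the change itself. A modest rise a 2.5-fold higher number from compound 1 to compound 4 (0.40 log units; beyond the scatter) is expected, though one within reach of the scatter cannot be excluded. Compound 4 is therefore estimated at 3000 nM in this assay, with a range from 800 nM to 12000 nM.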

Compound 4, half-maximal cytotoxic concentration: 81000 nM
Estimate against measurement, compound 4: 27-fold (1.43 log units) below, and the stated range ends below it.
By their numbers in this assay, from the lowest: compound 1; then compound 3; then compounds 2 and 4 (each within the scatter of the next).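

Chloro in place of methyl on this aromatic carbon gives a 68-fold higher number from compound 1 to compound 4 (1.83 log units; beyond the scatter) in this assay. The change swaps one heavy atom for one, with no ring, hydrogen-bond donor, hydrogen-bond acceptor or net charge entering or leaving, so this single place on the core of compound 1 can move the number far beyond the scatter. No measurement shown explains the size of this step. Going by these compounds, it remains open what an amine or a methoxy group at this place would give, and whether the step would carry over to another core.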